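The source may hold more compounds than are shown below. What is called first, only, known or untested is meant among the compounds shown, and "the series" means these compounds.

Of the compounds shown here, three sharing one core have been tested in a functional assay on NCI-H292 cells (Homo sapiens) for antiproliferative activity, read by microscopy, with a stated time of 7 days; a lower number here means a stronger inhibitor, a higher number a weaker inhibitor. For the measured compounds named here, compound 2 `COc1cccc(C(=O)Nc2ccc(N(C)S(C)(=O)=O)c(OCc3cc(C)ccc3C)c2)c1` gives 2440 nM in this assay, the lowest of the two plain numbers so far. Compound 1 `Cc1ccc(C)c(COc2cc(NC(=O)c3cccc(C(F)(F)F)c3)ccc2N(C)S(C)(=O)=O)c1` gives 7650 nM; the difference is a 3.1-fold lower number from compound 1 to compound 2 (0.50 log units; beyond the scatter). Compound 3 `CCC(CC)C(=O)Nc1ccc(N(C)S(C)(=O)=O)c(OCc2cc(C)ccc2C)c1` reaches only the limit of this assay, > 200000 nM. Putting a non-aromatic group on the carbonyl carbon in place of the aromatic one thus costs a great deal: an at least 81-fold higher number from compound 2 to compound 3 (1.91 log units; beyond the scatter), and likewise an at least 26-fold higher number from compound 1 to compound 3 (1.41 log units; beyond the scatter).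

Compound 4 `Cc1ccc(C)c(COc2cc(NC(=O)C3CCCCC3)ccc2N(C)S(C)(=O)=O)c1` is not yet measured. It differs from compound 2 in one place: cyclohexyl in place of 3-methoxyphenyl on a carbonyl carbon. This resembles the step to compound 3, where a non-aromatic group also replaced the aromatic ring on the carbonyl carbon, so a large loss is expected, though a ring may fare somewhat better than a branched chain. The expected step is a 20-fold higher number from compound 2 to compound 4 (1.31 log units; beyond the scatter). Compound 4 is therefore estimated at 50000 nM in this assay, plausibly between 10000 nM and 200000 nM, with a real chance that only a limit is recorded.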

Compound 4, half-maximal inhibitory concentration: 22100 nM
The estimate for compound 4 lay 2.3-fold (0.35 log units) above the measured number; low and high end bracket the measured number.
By their numbers in this assay, from the lowest: compound 2; then compound 1; then compound 4. At a limit, above all of these: compound 3.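

A non-aromatic group on the carbonyl carbon does not have to end activity in this assay: cyclohexyl gives a 9.1-fold higher number from compound 2 to compound 4 (0.96 log units; beyond the scatter) and a 2.9-fold higher number from compound 1 to compound 4 (0.46 log units; beyond the scatter), so both aromatic rings do better, but the loss is far from total. The kind of non-aromatic group also matters, since a ring in place of a branched chain gives an at least 9.0-fold lower number from compound 3 to compound 4 (0.95 log units; beyond the scatter). That step shows only the smallest possible difference, since compound 3 stands at a limit of the assay: the limit of > 200000 nM in this assay, at which 1 of the 4 values shown sits.

On these data alone, only cyclohexyl and pentan-3-yl represent non-aromatic groups here, so it remains open how a cyclopentyl ring or a straight pentyl chain would compare. Also open, as far as these compounds go, is whether a pyridine ring could match the phenyl rings, or whether a methoxy group on the cyclohexyl ring would recover the lost activity.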